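The compounds below may be only part of what the source reports. "The series", "measured", "known", "first", "only" and "open" are said of these compounds alone.

Working notes on the series in an ADME assay on Vero cells (Chlorocebus sabaeus) for cytotoxicity, read by MTT assay, with a stated time of 72 h; a lower number here means that less compound is tolerated, a higher number that more compound is tolerated: compound 1 `COc1c(N2C[C@H]3CCCN(Cc4cn(CCCN5C(=O)C(=O)c6cc(F)ccc65)nn4)[C@H]3C2)c(F)cc2c(=O)c(C(=O)O)cn(C3CC3)c12` gives 16 ug/mL, compound 2 `COc1c(N2C[C@H]3CCCN(Cc4cn(CCCN5C(=O)C(=O)c6cc(C)ccc65)nn4)[C@H]3C2)c(F)cc2c(=O)c(C(=O)O)cn(C3CC3)c12` gives 32 ug/mL, and compound 3 `CCO/N=C1/C(=O)N(CCCn2cc(CN3CCC[C@@H]4CN(c5c(F)cc6c(=O)c(C(=O)O)cn(C7CC7)c6c5OC)C[C@@H]43)nn2)c2ccccc21` gives 16 ug/mL. Compound 3 is level with compound 1 at these digits, and all three lie within the scatter of each other. Compound 4 `COc1c(N2C[C@H]3CCCN(Cc4cn(CCCN5C(=O)/C(=N/O)c6ccccc65)nn4)[C@H]3C2)c(F)cc2c(=O)c(C(=O)O)cn(C3CC3)c12` carries hydrogen in place of ethyl on an oxygen, ethoxy to hydroxy (hydrogen in place of ethyl on an oxygen). Within the data shown here, the one measured step, a 2.0-fold higher number from compound 1 to compound 2 (0.30 log units; within the scatter), is methyl in place of fluoro on an aromatic carbon, a different change, so it bears only loosely. Among the measured compounds shown here, no measured step covers the new change, and no step beyond the scatter is expected in this assay. The estimated step is no change at the digits printed from compound 3 to compound 4 (within the scatter). For compound 4 the expected value is 16 ug/mL, with an expected range of 8 ug/mL to 32 ug/mL.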

Compound 4, half-maximal cytotoxic concentration: 8 ug/mL
Compound 4: the middle estimate sits 2.0-fold (0.30 log units) above what was measured; the measured number falls inside the stated range.
By their numbers in this assay, from the lowest: compounds 4, 1, 3 and 2 (each within the scatter of the next, the first and the last beyond it).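

In this assay hydrogen in place of ethyl on an oxygen whose other neighbour is a double-bonded nitrogen gives a 2.0-fold lower number from compound 3 to compound 4 (0.30 log units; within the scatter) so at this position the change stays inside the scatter. Exchanging the whole group on the saturated chain carbon gives a 2.0-fold lower number from compound 1 to compound 4 (0.30 log units; within the scatter) and a 4.0-fold lower number from compound 2 to compound 4 (0.60 log units; beyond the scatter) with only the latter beyond the scatter, and modestly so. Nothing measured bears on the reason for these numbers. Still open, as far as these compounds go, is whether a propyl or benzyl group on this oxygen would stay within the scatter of compound 3. Also open, from the compounds shown here alone, is how a longer chain carrying a carboxylic acid would read there.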